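The compounds below may be only part of what the source reports. "The series", "measured", "known", "first", "only" and "open" are said of these compounds alone.

For the measured compounds named here, in a physicochemical assay for lipophilicity (on this read-out higher numbers stand for higher lipophilicity and lower numbers for lower lipophilicity), compound 3 `CCCOc1ccc2[nH]c(-c3ccc(OC)cc3)c(C3=C(Br)C(=O)NC3=O)c2c1` gives 3.12, the second highest of the three numbers measured so far. Compound 2 `CCCOc1ccc2[nH]c(-c3ccccc3)c(C3=C(Br)C(=O)NC3=O)c2c1` gives 3.16, and with a number 0.04 log units lower from compound 2 to compound 3 (within the scatter) the two cannot be told apart. Compound 1 `COc1ccc(-c2[nH]c3ccccc3c2C2=C(Br)C(=O)NC2=O)cc1` gives 2.42, and the step is a number 0.70 log units higher from compound 1 to compound 3 (beyond the scatter). Compound 4 `CCCCCCOc1ccc2[nH]c(-c3ccc(OC)cc3)c(C3=C(Br)C(=O)NC3=O)c2c1` differs from compound 3 by propyl in place of hydrogen on a saturated chain carbon, three bonds along the chain from an oxygen on an aromatic ring. Going by the values given here, the one measured step that bears on this is a number 0.70 log units higher from compound 1 to compound 3 (beyond the scatter), where propoxy replaced hydrogen on an aromatic carbon; a longer chain is expected to move the number in the same direction, beyond the scatter, by about a number 1.23 log units higher from compound 3 to compound 4 (beyond the scatter). Compound 4 is therefore estimated to give 4.35, with a range from 3.85 to 4.85.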

Compound 4, partition coefficient: 4.1
Estimate against measurement, compound 4: 0.25 log units above; measured number inside the range.
By their numbers in this assay, from the lowest: compound 1; then compounds 3 and 2 (each within the scatter of the next); then compound 4.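

Extending the chain by propyl gives a number 0.98 log units higher from compound 3 to compound 4 (beyond the scatter) in this assay and shows that this position still responds beyond propoxy. Measured against hydrogen on the aromatic carbon, propoxy gives a number 0.70 log units higher from compound 1 to compound 3 (beyond the scatter) and hexyloxy gives a number 1.68 log units higher from compound 1 to compound 4 (beyond the scatter) so the number rises with both chains, and the longer chain reaches the large step. No measurement here accounts for this rise.

As far as these compounds go, whether a longer chain, such as octyl, would raise the number further remains open. So does the effect of an amine or a carboxylic acid on this chain.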